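A few compounds are considered here, and "the series" means these few. Any claim that something is new, unique, unknown or untested is made for them only; others in the source may bear on it.

In an ADME assay on MT4 cells (Homo sapiens) for cytotoxicity, read by MTT assay, with a stated time of 5 days (a higher number here means that more compound is tolerated, a lower number that less compound is tolerated), compound 1 `Cc1cc(C)cc(Oc2cc(Nc3ccc(C#N)cc3)[nH]c(=O)c2I)c1` gives 24000 nM and compound 2 `Cc1cc(C)cc(Oc2cc(Nc3ccc(C#N)cc3)[nH]c(=O)c2Cl)c1` gives 21000 nM. These two numbers lie within the usual scatter of each other, so compound 2 stands level with compound 1. Compound 3 `Cc1cc(C)cc(Oc2cc(Nc3ccc(C#N)cc3)[nH]c(=O)c2)c1` has not yet been measured. Its structure differs from that of compound 2 as follows: hydrogen in place of chloro on an aromatic carbon. Put simply, it has hydrogen in place of chloro on an aromatic carbon. Among the compounds with values here, the only measured step at this carbon, a 1.1-fold lower number from compound 1 to compound 2 (0.06 log units; within the scatter), exchanged one group for another rather than removing it, so it is only a loose guide. That step stayed within the scatter, so no change beyond the scatter is expected here, and no direction can be favoured. The estimated change is a 1.0-fold higher number from compound 2 to compound 3 (0.02 log units; within the scatter). In this assay, the estimate for compound 3 is 22000 nM, with an expected range from 9000 nM to 50000 nM.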

Compound 3, half-maximal cytotoxic concentration: 46000 nM
For compound 3 the middle estimate is 2.1-fold (0.32 log units) below the measured one, within the range that was stated.
By their numbers in this assay, from the lowest: compounds 2, 1 and 3 (each within the scatter of the next, the first and the last beyond it).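

Taking the halogen off this carbon gives the first clear shift at this position in this assay: a 2.2-fold higher number from compound 2 to compound 3 (0.34 log units; beyond the scatter) is a modest move beyond the scatter. Removing iodo instead gives a 1.9-fold higher number from compound 1 to compound 3 (0.28 log units; within the scatter) and stays within the scatter, so the two removals do not separate as firmly, and the gain in tolerated compound cannot be called general for halogens at this carbon. Nothing available explains why the number moves here.

Going by these compounds, it remains open whether a larger number follows from hydrogen itself or from the loss of chloro in particular. A methyl group, a methoxy group or an amine on this carbon would show whether non-halogen groups stay level with the halogens or move towards hydrogen, and fluoro or bromo would test how far the halogen pattern extends.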